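Trimming the amide chain from compound 3 to compound 4

The source may hold more compounds than are shown below. What is called first, only, known or untested is meant among the compounds shown, and "the series" means these compounds.

Of the compounds shown here, three built on a shared core have been measured in a functional assay on HeLa cells (Homo sapiens) for antiproliferative activity, read by CCK-8 assay, with a stated time of 72 h; a higher number here means a weaker inhibitor of growth, a lower number a stronger inhibitor of growth. Compound 1 `CCC1C(=O)N(C)c2cnc(-n3ccc4cc(C(N)=O)ccc43)nc2N1c1ccn(C)n1` gives 27400 nM there. Compound 2 `CC[C@@H]1C(=O)N(C)c2cnc(Nc3ccc(S(=O)(=O)NC4CCCC4)cc3)nc2N1C1CCCC1` gives 609 nM in this assay. Compound 3 `CC[C@@H]1C(=O)N(C)c2cnc(-n3ccc4cc(C(=O)NCC(C)C)ccc43)nc2N1C1CCCC1` gives 3280 nM in this assay, the second highest number of the three: compound 2 shows the lower number and compound 1 the higher, and both gaps lie beyond the scatter. Compound 4 `CC[C@@H]1C(=O)N(C)c2cnc(-n3ccc4cc(C(=O)NC)ccc43)nc2N1C1CCCC1` has not yet been measured. It differs from compound 3 at a single place: hydrogen in place of isopropyl on a saturated chain carbon bound to an amide-type nitrogen. Among the compounds with values here, no measured pair traces this particular change on its own, since compound 1 carries a primary carboxamide but also a different group elsewhere on the core. Compound 4 is expected to show a somewhat higher number than compound 3, with the step of a 1.8-fold higher number from compound 3 to compound 4 (0.26 log units; within the scatter) expected to fall at or just beyond the scatter, because compound 1 with its primary carboxamide gives 27400 nM in this assay. For compound 4 in this assay the estimate is 6000 nM, within a range from 2000 nM to 20000 nM.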

Compound 4, concentration for 50% growth inhibition: 768 nM
For compound 4 the middle estimate is 7.8-fold (0.89 log units) above the measured one; measured number below the stated range.
By their numbers in this assay, from the lowest: compounds 2 and 4 (each within the scatter of the next); then compound 3; then compound 1.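

In this assay, within the data shown here, the amide chain can now be read on its own for the first time: going from isobutylcarbamoyl to methylcarbamoyl gives a 4.3-fold lower number from compound 3 to compound 4 (0.63 log units; beyond the scatter), so the isopropyl on this saturated chain carbon bound to an amide-type nitrogen is not required for growth inhibition, and its loss lowers the number. Compound 1 also carries a primary carboxamide but has a different group elsewhere on the core, so its high number cannot be attributed to the amide alone. No measurement shown here explains why the shorter chain gives the lower number.

As far as these compounds go, it remains open how a primary carboxamide would read on the core of compound 4. From the compounds shown here alone, it is also open whether an ethyl group, a longer chain ending in an amine or a carboxylic acid in the same place would follow this step.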